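Swapping an Imidazole Tail for a Hydroxypiperidine Tail

A few compounds are considered here, and "the series" means these few. Any claim that something is new, unique, unknown or untested is made for them only; others in the source may bear on it.

Compound 1 `O=C1c2c[n+]([O-])c3ccccc3c2C(=O)c2c1c1ccccc1n2CCCCn1ccnc1`: 240 nM
Compound 2 `O=C1c2c[n+]([O-])c3ccccc3c2C(=O)c2c1c1ccccc1n2Cc1cn(C[C@H](O)CO)nn1`: 400 nM
Compound 3 `CCCN1CCN(CCCCn2c3c(c4ccccc42)C(=O)c2c[n+]([O-])c4ccccc4c2C3=O)CC1`: 790 nM

These three compounds share one core and differ only in the chain hung on the aromatic nitrogen. In a functional assay on HCT-116 cells (Homo sapiens) for cytotoxicity, read by MTT assay, with a stated time of 72 h (on this read-out lower numbers stand for stronger inhibition and higher numbers for weaker inhibition), compound 1 gives 240 nM, the lowest of the three numbers. Compound 2 lies close to it: a 1.7-fold higher number from compound 1 to compound 2 (0.22 log units; within the scatter). Compound 3 lies furthest away: a 3.3-fold higher number from compound 1 to compound 3 (0.52 log units; beyond the scatter). The remaining step is a 2.0-fold higher number from compound 2 to compound 3 (0.30 log units; within the scatter).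

Compound 4 `O=C1c2c[n+]([O-])c3ccccc3c2C(=O)c2c1c1ccccc1n2CCCN1CCC(O)CC1` has not yet been measured. Against compound 1 the change is 4-hydroxypiperidin-1-yl in place of (1H-imidazol-1-yl)methyl on a saturated chain carbon, three bonds along the chain from an aromatic nitrogen. The step that bears most on this is the one in which 4-propylpiperazin-1-yl took the place of 1H-imidazol-1-yl, and that step was modest but beyond the scatter: a 3.3-fold higher number from compound 1 to compound 3 (0.52 log units; beyond the scatter). The other two steps stayed within the scatter, so they give no direction of their own. A modest rise in the number, that is weaker inhibition, is therefore expected in this assay, of roughly a 2.1-fold higher number from compound 1 to compound 4 (0.32 log units; beyond the scatter). Compound 4 is estimated at 500 nM, with a likely range from 200 nM to 1300 nM.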

Compound 4, half-maximal inhibitory concentration: 190 nM
Estimate against measurement, compound 4: 2.6-fold (0.42 log units) above; the whole stated range lies above it.
By their numbers in this assay, from the lowest: compounds 4, 1, 2 and 3 (each within the scatter of the next, the first and the last beyond it).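

In this assay, within the data shown here, the first step that replaces the five-membered aromatic ring of compound 1 with a six-membered non-aromatic ring carrying a hydroxyl group leaves the reading within the scatter: a 1.3-fold lower number from compound 1 to compound 4 (0.10 log units; within the scatter). The earlier step to compound 3 therefore cannot be read as a general cost of losing the 1H-imidazol-1-yl group, for the 4-hydroxypiperidin-1-yl chain reads clearly better than the 4-propylpiperazin-1-yl one, with a 4.2-fold lower number from compound 3 to compound 4 (0.62 log units; beyond the scatter), and it also stands beyond the scatter from the triazole chain, with a 2.1-fold lower number from compound 2 to compound 4 (0.32 log units; beyond the scatter). Nothing measured here accounts for these differences in cytotoxicity.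

Compound 4 carries its ring on a propyl chain where compound 1 has a butyl chain, so the ring and the chain length change together, and 3-(1H-imidazol-1-yl)propyl or 4-(4-hydroxypiperidin-1-yl)butyl would pull the two apart. As far as these compounds go, the role of the hydroxyl group also stays open, and a plain piperidin-1-yl or a morpholin-4-yl group on the same propyl chain would address it.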